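Aryl sulfonamide in place of methyl sulfonamide on a biphenyl methanol

The source may report more compounds than this note shows. Statements on the series, on what has been measured and on what is new or still open speak of the compounds shown alone.

The compounds measured so far:
compound 1, `CN(C(=O)c1ccccc1)c1cccc(-c2ccc(CO)cc2)c1` — < 10%
compound 2, `CS(=O)(=O)Nc1ccc(-c2ccc(CO)cc2)cc1` — < 10%

Of the compounds shown here, two have been measured in an assay for binding affinity to 17-beta-hydroxysteroid dehydrogenase type 1 (Homo sapiens), with a stated time of 20 min, tested at 1 uM; on this read-out higher numbers stand for more inhibition at the one concentration tested (going by the name of the read-out) and lower numbers for less inhibition. Compound 1 is `CN(C(=O)c1ccccc1)c1cccc(-c2ccc(CO)cc2)c1` and in this assay it gives < 10%, which is a limit of the assay rather than a number. Compound 2 is `CS(=O)(=O)Nc1ccc(-c2ccc(CO)cc2)cc1` and in this assay it gives < 10%, again a limit. Compound 2 therefore sits at the floor of what this assay reports, as stated by the limit of < 10% in this assay, at which 2 of the 2 values shown sit. Among the compounds with values here, no step between two measured compounds can be computed, and so there is no measured change of this read-out to lean on.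

Compound 3 is `Cc1cccc(S(=O)(=O)Nc2ccc(-c3ccc(CO)cc3)cc2)c1`. Its difference from compound 2 is 3-methylphenyl in place of methyl on a sulfonyl sulfur. Nothing measured here tells how such a change moves this assay, so the expected step from compound 2 to compound 3 is estimated as small and most likely within the scatter, with only a modest chance of an upward move, a number at least 5 percentage points higher from compound 2 to compound 3 (that floor lies within the scatter). Compound 3 is accordingly expected to give about 15% in this assay, within a range from 0% to 45%.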

Compound 3, a percentage reported as inhibition, at one concentration (the size of the read-out at that concentration, not a potency): < 10%
Compound 3: no number, only a limit; the forecaster's own chance of this, stated with the estimate: 55%; at least 5 percentage points between middle value and limit.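

No step can be read from compound 2 to compound 3, because both values are limits rather than numbers, and both sit at the floor of this assay: the limit of < 10% in this assay, at which 3 of the 3 values shown sit. The compounds shown leave open which change to the shared core, if any, would lift inhibition clear of that floor, and by how much.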